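From methoxy to amino on a shared core

The source may hold more compounds than are shown below. What is called first, only, known or untested is meant among the compounds shown, and "the series" means these compounds.

Three compounds sharing one core were measured in an ADME assay on L6 cells (Rattus norvegicus) for cytotoxicity, read by resazurin assay, with a stated time of 72 h (a lower number here means a stronger inhibitor, a higher number a weaker inhibitor), and differ in one group. Compound 1 `CC(C)(C)c1ccc(C(=O)NC(=O)c2ccccc2O)cc1` reads 2.3 ug/mL and compound 3 `COc1ccc(C(=O)NC(=O)c2ccccc2O)cc1` reads 39 ug/mL as the higher of these two numbers. Compound 2 `CS(=O)(=O)c1ccc(C(=O)NC(=O)c2ccccc2O)cc1` reads > 100 ug/mL as a limit of the assay, not a number. Compound 4 `Nc1ccc(C(=O)NC(=O)c2ccccc2O)cc1` carries amino in place of methoxy on an aromatic carbon and is not yet measured. Replacing tert-butyl gave large steps: an at least 43-fold higher number from compound 1 to compound 2 (1.63 log units; beyond the scatter) and a 17-fold higher number from compound 1 to compound 3 (1.23 log units; beyond the scatter) in turn. Swapping methylsulfonyl for methoxy gave an at least 2.5-fold lower number from compound 2 to compound 3 (0.40 log units; beyond the scatter) as the third step. None of these steps involves amino, so the value of compound 3 39 ug/mL stays the guide and no step beyond the scatter is expected in this assay for this change. The expected step is a 1.2-fold higher number from compound 3 to compound 4 (0.06 log units; within the scatter) on this reasoning. For compound 4 the estimated value is 45 ug/mL with an expected range from 15 ug/mL to 100 ug/mL in this estimate.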

Compound 4, half-maximal inhibitory concentration: 39 ug/mL
Estimate against measurement, compound 4: 1.2-fold (0.06 log units) above; the range from low to high includes it.
By their numbers in this assay, from the lowest: compound 1; then compounds 3 and 4 (each within the scatter of the next). At a limit, above all of these: compound 2.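

In this assay, amino in place of methoxy on this aromatic carbon gives no change at the digits printed from compound 3 to compound 4 (within the scatter) even though the change adds a hydrogen-bond donor. Amino in place of tert-butyl gives a 17-fold higher number from compound 1 to compound 4 (1.23 log units; beyond the scatter) and so matches the step already seen for methoxy. Amino in place of methylsulfonyl gives an at least 2.5-fold lower number from compound 2 to compound 4 (0.40 log units; beyond the scatter) as a bound only, for compound 2 stands at a limit of the assay: the limit of > 100 ug/mL in this assay, at which 1 of the 4 values shown sits.

Still open, as far as these compounds go, is how a larger amine such as dimethylamino, or a carboxylic acid, would read at this place.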